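Second diazeniumdiolate nitrogen: dimethylamino to carbamoylpiperazinyl

The source may hold more compounds than are shown below. What is called first, only, known or untested is meant among the compounds shown, and "the series" means these compounds.

Compound 2 `CCN(CC)C(=O)N1CCN(/[N+]([O-])=N/Oc2cc(O/N=[N+](\[O-])N(C)C)c([N+](=O)[O-])cc2[N+](=O)[O-])CC1` gives 1900 nM in a functional assay on HL-60 cells (Homo sapiens) for antiproliferative activity, read by MTT assay, with a stated time of 72 h; on this read-out higher numbers stand for weaker inhibition and lower numbers for stronger inhibition; compound 1 `CCOC(=O)N1CCN(/[N+]([O-])=N/Oc2cc(O/N=[N+](\[O-])N(C)C)c([N+](=O)[O-])cc2[N+](=O)[O-])CC1` gives 1200 nM, and a 1.6-fold higher number from compound 1 to compound 2 (0.20 log units; within the scatter), so the two numbers are not distinguishable. Compound 3 `CCOC(=O)N1CCN(/[N+]([O-])=N/Oc2cc(O/N=[N+](\[O-])N3CCN(C(=O)N(CC)CC)CC3)c([N+](=O)[O-])cc2[N+](=O)[O-])CC1` carries 4-(ethoxycarbonyl)piperazin-1-yl in place of dimethylamino on a double-bonded nitrogen. For the measured compounds named here, no measured step touches that position: the only step known, a 1.6-fold higher number from compound 1 to compound 2 (0.20 log units; within the scatter), concerns the carbonyl substituent on the other piperazine and offers no direction. The expectation is therefore no step beyond the scatter. Compound 3 is expected at 1500 nM, with a range of 500 nM to 4500 nM, which would mean an expected 1.3-fold lower number from compound 2 to compound 3 (0.10 log units; within the scatter).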

Compound 3, half-maximal inhibitory concentration: 900 nM
For compound 3 the middle estimate is 1.7-fold (0.22 log units) above the measured one; the range from low to high includes it.
By their numbers in this assay, from the lowest: compounds 3, 1 and 2 (each within the scatter of the next, the first and the last beyond it).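

On the double-bonded nitrogen, 4-(ethoxycarbonyl)piperazin-1-yl can replace dimethylamino in this assay with no loss of inhibition (a 2.1-fold lower number from compound 2 to compound 3 (0.32 log units; beyond the scatter)). For the compounds shown here, this modest step is the first beyond the scatter, and it shows that this position responds to its substituent and accepts a six-membered ring with two hetero atoms. Nothing available bears on the origin of the step.

Going by these compounds, it remains open whether the ring or the ethoxycarbonyl group accounts for the step. An unsubstituted piperazine or a morpholine at this position would separate the two.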